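The source may hold more compounds than are shown below. What is called first, only, known or untested is meant among the compounds shown, and "the series" means these compounds.

Measured so far, in a functional assay on Bel-7402 cells (Homo sapiens) for cytotoxicity, read by MTT assay; a lower number here means a stronger inhibitor, a higher number a weaker inhibitor:

Compound 1, `Cc1nc(Nc2ccccc2)sc1C(=O)/C=C/c1ccc(Cl)cc1`: > 25000 nM, a limit of the assay and not a number.
Compound 2, `Cc1ccc(Nc2nc(C)c(C(=O)/C=C/c3ccc(Cl)cc3)s2)cc1`: > 25000 nM, again only a limit.
Compound 3, `COc1cc(/C=C/C(=O)c2sc(Nc3ccccc3)nc2C)cc(OC)c1OC`: > 25000 nM, once more only a limit.

All three values sit at the same ceiling, which is the whole of the evidence here: the limit of > 25000 nM in this assay, at which 3 of the 3 values shown sit. Compound 1 and compound 2 differ by one change, (methyl in place of hydrogen on an aromatic carbon), but a step that the two limits leave unreadable from compound 1 to compound 2, since both ends are limits. The difference between the core of compound 1 and the core of compound 3 is not broken down here.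

Compound 4, `COc1cc(/C=C/C(=O)c2sc(Nc3ccc(C)cc3)nc2C)cc(OC)c1OC`, is not yet measured. It stands to compound 3 as compound 2 stands to compound 1: the change is methyl in place of hydrogen on an aromatic carbon, the same change at the same kind of place. Among the measured compounds shown here, because the only measured step of this change, a step that the two limits leave unreadable from compound 1 to compound 2, moved a compound from one limit to another limit, and because the limit of > 25000 nM in this assay, at which 3 of the 3 values shown sit, holds for every value shown, the expected step that the limit leaves unreadable from compound 3 to compound 4 rests on no readable number. The estimate for compound 4 in this assay is therefore 40000 nM, between 15000 nM and 120000 nM, most likely again reported only as a limit.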

Compound 4, half-maximal inhibitory concentration: > 25000 nM
Compound 4 was reported as a limit; the forecaster's own chance of this, stated with the estimate: 85%; the middle value does not contradict the limit.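

Compound 3 and compound 4 are both reported only as limits, so putting methyl in place of hydrogen gives no readable step between them, and the same holds for every pair here: the limit of > 25000 nM in this assay, at which 4 of the 4 values shown sit. The compounds shown leave open how strongly any of them acts in this assay, and whether this methyl changes that at all.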